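Compound 3: 2-nitrophenyl analogue of compound 2

The source may report more compounds than this note shows. Statements on the series, on what has been measured and on what is new or still open speak of the compounds shown alone.

Within the data shown here, compound 2 `O=C1NC(=O)/C(=C/c2ccc(OCCSc3nnc(-c4ccc([N+](=O)[O-])cc4)[nH]3)cc2)S1` gives 18% in a functional assay on the whole organism (plasma, strain Wistar) with Rattus norvegicus as the target, with a stated time of 15 days, at a dose of 100 mg/kg by the oral route (on this read-out higher numbers stand for a stronger effect at the one dose given and lower numbers for a weaker effect), and stands lowest of the two numbers measured so far; compound 1 `Cc1ccc(-c2nnc(SCCOc3ccc(/C=C4\SC(=O)NC4=O)cc3)[nH]2)cc1` gives 29.7%, and the change a number 11.7 percentage points lower from compound 1 to compound 2 (beyond the scatter), arising from nitro in place of methyl on an aromatic carbon. Compound 3 `O=C1NC(=O)/C(=C/c2ccc(OCCSc3nnc(-c4ccccc4[N+](=O)[O-])[nH]3)cc2)S1` differs from compound 2 by 2-nitrophenyl in place of 4-nitrophenyl on an aromatic carbon. Among the measured compounds shown here, no measured step moves a group around a ring, so the single step available, a number 11.7 percentage points lower from compound 1 to compound 2 (beyond the scatter), does not bear directly on this change. No step beyond the scatter is expected, a number 1 percentage points higher from compound 2 to compound 3 (within the scatter). Compound 3 is therefore estimated at 19%, within 8% to 31%.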

Compound 3, a percentage reported as activity, at one dose (the size of the read-out at that dose, not a potency): 26.8%
The estimate for compound 3 lay 7.8 percentage points below the measured number; measured number inside the range.
By their numbers in this assay, from the lowest: compounds 2, 3 and 1 (each within the scatter of the next, the first and the last beyond it).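

In this assay, among these compounds, the move from 4-nitrophenyl to 2-nitrophenyl gives the first reading on where the nitro group sits on the phenyl ring, and it is a number 8.8 percentage points higher from compound 2 to compound 3 (within the scatter) so the two positions are not separated here. With 2-nitrophenyl in place of 4-methylphenyl the result is a number 2.9 percentage points lower from compound 1 to compound 3 (within the scatter) so the separation from compound 1 seen with 4-nitrophenyl does not appear with 2-nitrophenyl. Nothing measured here explains either step. Open, on these data alone, is whether an amine or a carboxylic acid in place of the nitro group would separate from compound 1.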